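Swapping 2-fluorophenyl for 3-methylphenyl in compound 4

The source may report more compounds than this note shows. Statements on the series, on what has been measured and on what is new or still open speak of the compounds shown alone.

Measured so far in an ADME assay on L929 cells (Mus musculus) for cytotoxicity, read by resazurin assay, with a stated time of 96 h; on this read-out lower numbers stand for higher toxicity in this test and higher numbers for lower toxicity in this test:
Compound 1 `Cc1n[nH]c2c1[C@@H](c1ccc(OCc3ccccc3F)cc1)S[C@@H](C)C(=O)N2`: > 200000 nM
Compound 2 `Cc1n[nH]c2c1[C@@H](c1ccc(OCc3cccc(F)c3)cc1)S[C@@H](C)C(=O)N2`: 103000 nM
Compound 3 `Cc1n[nH]c2c1[C@@H](c1ccc(OCc3ccc(F)cc3)cc1)S[C@@H](C)C(=O)N2`: "not determined" (no result reported)

Compound 1 gives > 200000 nM in this assay, which is a limit of the assay and not a number. It therefore stands at the limit of > 200000 nM in this assay, at which 1 of the 3 values shown sits. Compound 3 adds no number to the comparison.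

Compound 4 `Cc1cccc(COc2ccc([C@H]3S[C@@H](C)C(=O)Nc4[nH]nc(C)c43)cc2)c1` has not yet been measured. The change leading to it from compound 1 is 3-methylphenyl in place of 2-fluorophenyl on a saturated chain carbon bound to an oxygen on an aromatic ring.

Among the measured compounds shown here, one measured step bears on this change, an at least 1.9-fold lower number from compound 1 to compound 2 (0.28 log units; that floor lies within the scatter). It also removes the 2-fluorophenyl, and the group it brings in, 3-fluorophenyl, is the closest by name to 3-methylphenyl. For the measured compounds named here, compound 2 gives 103000 nM, and this is the only firm number available. A step of similar modest size towards a lower number in this assay is therefore expected, though the direction is not secure. The estimated step is an at least 2.0-fold lower number from compound 1 to compound 4 (0.30 log units; that floor lies within the scatter). For compound 4 the estimated value is 100000 nM, with an expected range from 40000 nM to 200000 nM.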

Compound 4, concentration lethal to 50% of the cells: 98900 nM
Estimate against measurement, compound 4: 1.0-fold (0.00 log units) above, and the stated range covers the measured number.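

In this assay, among the compounds shown here, the one step with a firm number at both ends is a 1.0-fold lower number from compound 2 to compound 4 (0.02 log units; within the scatter), so methyl in place of fluoro on an aromatic carbon gives two values that cannot be told apart. For the compounds shown here, this is something the earlier compounds could not show, and it means that 3-methylphenyl and 3-fluorophenyl read alike at this place, on a saturated chain carbon bound to an oxygen on an aromatic ring. Leaving 2-fluorophenyl for 3-methylphenyl reads as an at least 2.0-fold lower number from compound 1 to compound 4 (0.30 log units; that floor lies within the scatter), and the comparison rests on a limit of the assay, not a number, for compound 1: the limit of > 200000 nM in this assay, at which 1 of the 4 values shown sits.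

The compounds shown therefore leave open whether 2-fluorophenyl truly differs from the two groups that replace it, since the true value of compound 1 is unknown and the floor of each step lies within the scatter. They also leave open how this read-out would respond to an amine or a carboxylic acid in place of the methyl on that aromatic carbon.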